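Trading Trifluoromethyl for Fluoro in Compound 4

The source may hold more compounds than are shown below. What is called first, only, known or untested is meant among the compounds shown, and "the series" means these compounds.

Of the compounds shown here, three that share one core have been measured in a functional assay on HCT-116 cells (Homo sapiens) for antiproliferative activity, read by MTT assay, with a stated time of 72 h; on this read-out lower numbers stand for stronger inhibition and higher numbers for weaker inhibition. Compound 1 `O=C(CSc1ccc(Cl)cc1)Nc1ccc2nc(NC(=O)c3ccc4ccccc4c3)sc2c1` gives 4040 nM, compound 2 `Cc1ccc(SCC(=O)Nc2ccc3nc(NC(=O)c4ccc(C(F)(F)F)cc4)sc3c2)c(C)c1` gives 320 nM, and compound 3 `O=C(CSc1ccc(Cl)cc1)Nc1ccc2nc(NC(=O)c3ccc(C(F)(F)F)cc3)sc2c1` gives 930 nM. Compound 3 therefore stands second highest of the three numbers, set apart from both neighbours by the steps of a 4.3-fold lower number from compound 1 to compound 3 (0.64 log units; beyond the scatter) and a 2.9-fold higher number from compound 2 to compound 3 (0.46 log units; beyond the scatter).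

Compound 4 `O=C(CSc1ccc(Cl)cc1)Nc1ccc2nc(NC(=O)c3ccc(F)cc3)sc2c1` differs from compound 3 in a single place: fluoro in place of trifluoromethyl on an aromatic carbon. Of the measured steps, only the exchange on the carbonyl carbon, a 4.3-fold lower number from compound 1 to compound 3 (0.64 log units; beyond the scatter), touches the same arm of the molecule, and it was modest; the exchange on the sulfur, a 2.9-fold higher number from compound 2 to compound 3 (0.46 log units; beyond the scatter), concerns the other arm. For the measured compounds named here, no measured pair compares trifluoromethyl with fluoro directly, so the direction is uncertain, and a change no larger than the modest steps already seen is expected. For compound 4 the author estimates 1500 nM, within 500 nM to 4500 nM, which means an expected step of a 1.6-fold higher number from compound 3 to compound 4 (0.21 log units; within the scatter).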

Compound 4, half-maximal inhibitory concentration: 1360 nM
Estimate against measurement, compound 4: 1.1-fold (0.04 log units) above; the range from low to high includes it.
By their numbers in this assay, from the lowest: compound 2; then compounds 3 and 4 (each within the scatter of the next); then compound 1.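

In this assay, the exchange of trifluoromethyl for fluoro gives a 1.5-fold higher number from compound 3 to compound 4 (0.17 log units; within the scatter) and so stays inside the scatter: three fewer heavy atoms at this place, with the same count of hydrogen-bond donors and acceptors, leave no separable difference in this read-out. The exchange of naphthalen-2-yl gives a 3.0-fold lower number from compound 1 to compound 4 (0.47 log units; beyond the scatter) with 4-fluorophenyl as the incoming group, so the lower number seen with 4-(trifluoromethyl)phenyl recurs with a second group, and neither compound 3 nor compound 4 goes against this. No measured evidence here explains either step.

On these data alone, it remains open whether a more different group at this place, such as an amine, a carboxylic acid or a longer alkyl chain, would move the number beyond the scatter. As far as these compounds go, it also remains open whether 4-fluorophenyl would behave the same way alongside the 2,4-dimethylphenyl on the sulfur of compound 2.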